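Iodo for hydrogen on the core of compound 1

The source may hold more compounds than are shown below. What is called first, only, known or untested is meant among the compounds shown, and "the series" means these compounds.

Compound 1 `COCCN/C(=C1/N=CN(CCOC)C1=O)c1cc2ccccc2[nH]1` gives 73.7% in an assay on isolated protein for inhibition of Calpain-1 catalytic subunit (Homo sapiens), read by fluorescence, with a stated time of 60 min, tested at 1 uM (a lower number here means less inhibition, a higher number more inhibition at the concentration tested (going by the name of the read-out)), the highest of the three numbers shown; compound 3 `COCCN1C=N/C(=C(/NCCN(C)C)c2cc3ccccc3[nH]2)C1=O` gives 64.6% and compound 2 `COCCN/C(=C1/N=C(c2ccccc2)N(CCOC)C1=O)c1cc2ccccc2[nH]1` gives 21.5%. The step of a number 9.1 percentage points lower from compound 1 to compound 3 (within the scatter) stays within the scatter, whereas a number 52.2 percentage points lower from compound 1 to compound 2 (beyond the scatter) is large. Compound 4 `COCCN/C(=C1/N=CN(CCOC)C1=O)c1[nH]c2ccccc2c1I` differs from compound 1 by iodo in place of hydrogen on an aromatic carbon. Going by the values given here, neither measured step touches an aromatic carbon of the core: one changes a carbon with a double bond to nitrogen, the other a saturated chain carbon, so no measured step bears directly on this change. The expected step is a number 15.7 percentage points lower from compound 1 to compound 4 (beyond the scatter), a moderate loss with wide uncertainty. For compound 4 the expected value is 58%, with a range from 25% to 85%.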

Compound 4, a percentage reported as inhibition, at one concentration (the size of the read-out at that concentration, not a potency): 76.8%
For compound 4 the middle estimate is 18.8 percentage points below the measured one; the range from low to high includes it.
By their numbers in this assay, from the lowest: compound 2; then compounds 3, 1 and 4 (each within the scatter of the next, the first and the last beyond it).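

Iodo in place of hydrogen gives a number 3.1 percentage points higher from compound 1 to compound 4 (within the scatter) in this assay and so shows that this aromatic carbon of the five-membered aromatic ring can carry iodo with the number held at the level of compound 1. The earlier compounds shown here showed no change on this ring, and the large step of a number 52.2 percentage points lower from compound 1 to compound 2 (beyond the scatter) does not carry over to this position. Nothing measured here gives a reason for this result.

Going by these compounds, whether fluoro, methyl or an amine on the same aromatic carbon would hold the number stays open. So does whether iodo combines with the dimethylamino chain of compound 3.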